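This account rests on a few compounds, and the source may have more. Where it says the series, first, only, none or still open, it means among the compounds named here.

Measured compounds:
- compound 1, `CC(C)N1CC[C@H](NC(=O)c2cc(-c3ccc(NS(=O)(=O)c4cccc(Cl)c4Cl)cc3)nc3[nH]ncc23)C1`: 4 nM
- compound 2, `O=C(NC1CCN(C2CC2)C1)c1cc(-c2ccc(NS(=O)(=O)c3cccc(Cl)c3Cl)cc2)nc2[nH]ncc12`: 6 nM
- compound 3, `CC(C)NC(=O)c1cc(-c2ccc(NS(=O)(=O)c3cccc(Cl)c3Cl)cc2)nc2[nH]ncc12`: 68 nM

In an assay for inhibition of serine/threonine-protein kinase Sgk1 (Homo sapiens), with stated times of 30 min and 60 min, in the presence of a further agent that is not named here (on this read-out higher numbers stand for weaker inhibition and lower numbers for stronger inhibition), compound 1 gives the lowest of the three numbers; compound 2 sits within the scatter of it, while compound 3 stands far higher. Compound 4, `NCCNC(=O)c1cc(-c2ccc(NS(=O)(=O)c3cccc(Cl)c3Cl)cc2)nc2[nH]ncc12`, is not yet measured. It differs from compound 1 by 2-aminoethyl in place of 1-isopropylpyrrolidin-3-yl on an amide-type nitrogen. For the measured compounds named here, two steps bear on this change: a 17-fold higher number from compound 1 to compound 3 (1.23 log units; beyond the scatter) and an 11-fold higher number from compound 2 to compound 3 (1.05 log units; beyond the scatter), both of which exchange the whole 1-substituted pyrrolidin-3-yl group for a small group without a ring, and both weaken inhibition markedly. The step of a 1.5-fold higher number from compound 1 to compound 2 (0.18 log units; within the scatter) shows that the group on the pyrrolidine ring matters little. Since compound 4 likewise loses the ring but keeps a chain carrying a nitrogen, a weakening, expected to be smaller than from compound 1 to compound 3, seems likely; the estimated step is a 3.8-fold higher number from compound 1 to compound 4 (0.57 log units; beyond the scatter). Compound 4 is expected to give about 15 nM, between 5 nM and 50 nM.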

Compound 4, half-maximal inhibitory concentration: < 1 nM
Compound 4: no number, only a limit; the forecaster's own chance of this, stated with the estimate: 0%; at least 15-fold (1.17 log units) between middle value and limit.
By their numbers in this assay, from the lowest: compounds 1 and 2 (each within the scatter of the next); then compound 3. At a limit, below all of these: compound 4.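

Compound 4 gives < 1 nM in this assay, which is a limit and not a number. The pyrrolidine ring is therefore not required at this amide-type nitrogen, as 2-aminoethyl gives an at least 4.0-fold lower number from compound 1 to compound 4 (0.60 log units; beyond the scatter) and an at least 6.0-fold lower number from compound 2 to compound 4 (0.77 log units; beyond the scatter). Among groups without a ring, the outcome also depends on the group chosen, since the step from isopropyl to 2-aminoethyl is an at least 68-fold lower number from compound 3 to compound 4 (1.83 log units; beyond the scatter).

From the compounds shown here alone, how far the true value lies past the limit remains open. So does whether a 2-hydroxyethyl, 2-(dimethylamino)ethyl or 3-aminopropyl group would match 2-aminoethyl.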